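Replacing the phenethyl side chain of a cathepsin S inhibitor

The compounds below may be only part of what the source reports. "The series", "measured", "known", "first", "only" and "open" are said of these compounds alone.

Compound 3 `CC(C)(C)C[C@H](NC(=O)N1CCOCC1)C(=O)N[C@H](C#N)CCc1ccccc1` gives 23 nM in an assay for inhibition of cathepsin S (Homo sapiens) (a lower number here means a stronger inhibitor, a higher number a weaker inhibitor), the lowest number among the three measured compounds. Its nearest neighbour is compound 2 `N#C[C@H](CCc1ccccc1)NC(=O)[C@@H](NC(=O)N1CCOCC1)C1CCCCC1`, which gives 84 nM, and the furthest is compound 1 `CC(C)[C@H](NC(=O)N1CCOCC1)C(=O)N[C@H](C#N)CCc1ccccc1`, which gives 6000 nM. The measured steps all concern a single position: a 71-fold lower number from compound 1 to compound 2 (1.85 log units; beyond the scatter), a 260-fold lower number from compound 1 to compound 3 (2.42 log units; beyond the scatter) and a 3.7-fold lower number from compound 2 to compound 3 (0.56 log units; beyond the scatter).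

Compound 4 `Cc1ccccc1COC[C@@H](C#N)NC(=O)[C@H](CC(C)(C)C)NC(=O)N1CCOCC1` keeps the neopentyl group of compound 3 and changes the other end of the molecule: (2-methylbenzyl)oxy in place of benzyl on a saturated chain carbon, two bonds along the chain from an amide-type nitrogen and a triple-bonded carbon. For the measured compounds named here, none of the measured steps touches this position, so they give no direct guidance on how large the step should be or in which direction; they show only that the shared core tolerates substantial variation elsewhere while remaining a strong inhibitor.

With nothing measured at this position, the step from compound 3 to compound 4 is expected to stay close to the scatter, a 1.5-fold lower number from compound 3 to compound 4 (0.19 log units; within the scatter), with the wide uncertainty that follows from the lack of a comparable step. Compound 4 is therefore estimated at 15 nM in this assay, within a range from 3 nM to 80 nM.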

Compound 4, half-maximal inhibitory concentration: 12 nM
Compound 4: middle estimate off by 1.3-fold (0.10 log units), on the high side; the range from low to high includes it.
By their numbers in this assay, from the lowest: compounds 4 and 3 (each within the scatter of the next); then compound 2; then compound 1.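

In this assay, the exchange of benzyl for (2-methylbenzyl)oxy amounts to a 1.9-fold lower number from compound 3 to compound 4 (0.28 log units; within the scatter) and so leaves the two compounds indistinguishable in this measurement. For the compounds shown here, all the earlier steps concerned the position carrying isopropyl, cyclohexyl or neopentyl, and all of them lay beyond the scatter; this one shows that the other position, on a saturated chain carbon, two bonds along the chain from an amide-type nitrogen and a triple-bonded carbon, can take a group with more heavy atoms and a hydrogen-bond acceptor, with the number remaining in the same range. No available measurement speaks to the reason for this result.

The change brings in the oxygen and the methyl together, so the compounds shown do not separate what each contributes, and they do not show whether an amine, a carboxylic acid or a longer chain would be accepted here in the same way. Going by these compounds, it also remains open whether (2-methylbenzyl)oxy would give a similarly small step alongside isopropyl or cyclohexyl instead of neopentyl.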